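Amide nitrogen substituent change in an inactive series

The compounds below may be only part of what the source reports. "The series", "measured", "known", "first", "only" and "open" are said of these compounds alone.

Three compounds built on one shared core were examined in a functional assay on HeLa cells (Homo sapiens) for cytotoxicity, read by MTT assay, with a stated time of 24 h; on this read-out higher numbers stand for weaker inhibition and lower numbers for stronger inhibition. Compound 1 `C=CC1=C(C(=O)NCc2ccc(Cl)cc2)C(c2ccc(OC)cc2)OC1` carries a 4-chlorobenzyl group on its amide-type nitrogen. In this assay compound 1 gives > 100000 nM, which is a limit of the assay rather than a number. Compound 2 `C=CC1=C(C(=O)NCCC)C(c2ccc(OC)c(OC)c2)OC1` in this assay gives > 100000 nM, likewise a limit. Compound 3 `C=CC1=C(C(=O)NCCC)C(c2ccc(Cl)c(Cl)c2)OC1` in this assay gives > 100000 nM, also a limit. Among the compounds with values here, compound 1 thus stands exactly where its two companions stand, at the limit of > 100000 nM in this assay, at which 3 of the 3 values shown sit, and no measured number separates it from compound 2 or compound 3; no step between measured compounds can be read from these data.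

Compound 4 `C=CC1=C(C(=O)Nc2ccc(OCC)cc2)C(c2ccc(OC)cc2)OC1` has not yet been measured. It differs from compound 1 in a single place: 4-ethoxyphenyl in place of 4-chlorobenzyl on an amide-type nitrogen. Because compound 1, compound 2 and compound 3 all sit at the limit of > 100000 nM in this assay, at which 3 of the 3 values shown sit, there is nothing to show whether any change on the amide-type nitrogen moves the read-out in either direction. The step in this assay is expected to be a number no higher from compound 1 to compound 4 (the limit leaves the size open), that is, none beyond the scatter. Compound 4 is therefore expected to give about 100000 nM in this assay, within a range from 30000 nM to 300000 nM, and most probably the assay will again report only a limit for it.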

Compound 4, half-maximal inhibitory concentration: > 100000 nM
Compound 4: no number, only a limit; the forecaster's own chance of this, stated with the estimate: 75%; the middle value sits exactly at the limit.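

In this assay compound 4 gives > 100000 nM, which is a limit of the assay and not a number. Within the data shown here, no step from compound 1 to compound 4 can be read, because both sit at the same limit: the limit of > 100000 nM in this assay, at which 4 of the 4 values shown sit. The compounds shown leave open whether any group on the amide-type nitrogen changes the read-out at all.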